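Fluoro in Place of Methyl on a Shared Core

A few compounds are considered here, and "the series" means these few. Any claim that something is new, unique, unknown or untested is made for them only; others in the source may bear on it.

Of the compounds shown here, three built on one shared core have been tested in a functional assay on the whole organism with Mus musculus as the target, with a stated time of 1 h, at a dose of 100 mg/kg by the intraperitoneal route; a higher number here means more inhibition at the dose given (going by the name of the read-out), a lower number less inhibition. Compound 1 `Brc1ccccc1COc1nc2ccccc2s1` carries a bromo group and gives 75.6%. Compound 3 `Fc1cccc(COc2nc3ccccc3s2)c1` carries a fluoro group and gives 86.8%. Compound 2 `Cc1ccc(COc2nc3ccccc3s2)cc1`, which carries a methyl group, gives 1.95% and so stands lowest of the three; its gap to compound 1 and its gap to compound 3 each lie beyond the usual scatter of repeated measurements, so the number of compound 2 is clearly the lowest of the three.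

Compound 4 `Fc1ccc(COc2nc3ccccc3s2)cc1` has not yet been measured in this assay. Set against compound 2 it differs in one place: fluoro in place of methyl on an aromatic carbon. Within the data shown here, no measured pair in this set differs in exactly this way, so the size of the step has to be judged from the whole picture.

The two compounds that carry a bromo or a fluoro group, compound 1 with 75.6% and compound 3 with 86.8%, both sit far above compound 2. Whether the low number of compound 2 rests on the methyl itself or on its place para to a large group cannot be told from three compounds. Still, a fluoro group on the ring has gone with high inhibition once already, so an upward step beyond the scatter is expected, namely a number 53.1 percentage points higher from compound 2 to compound 4 (beyond the scatter). For compound 4 the estimated value is 55%, with an expected range from 10% to 90%.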

Compound 4, a percentage reported as inhibition, in the whole organism at one dose (the size of the read-out at that dose, not a potency): 90.7%
For compound 4 the middle estimate is 35.7 percentage points below the measured one; measured number above the stated range.
By their numbers in this assay, from the lowest: compound 2; then compound 1; then compounds 3 and 4 (each within the scatter of the next).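

In this assay the change from methyl to fluoro on this aromatic carbon, para to a large group, gives a number 88.8 percentage points higher from compound 2 to compound 4 (beyond the scatter) and so carries the compound from almost no inhibition to high inhibition at the dose given. This shows that a substituent at this place on the ring is compatible with high inhibition, so the place itself does not bring the low number of compound 2; with these two compounds, the difference follows the swap of methyl for fluoro. Compound 4 gives 90.7% and compound 3, with its fluoro group at another place on the ring, gives 86.8% as a value within the usual scatter of the first, so this pair shows no readable effect of moving the fluoro group.

The compounds shown leave open whether methyl alone gives so low a number here or whether a chloro, a methoxy or an amine at the same carbon would do the same, and a single dose gives no measure of potency. Nothing available here explains why this one swap makes so large a difference.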